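The compounds below may be only part of what the source reports. "The series", "measured", "known", "first", "only" and "open" are said of these compounds alone.

Working notes on the series. In an assay on LtK cells with ATP-sensitive inward rectifier potassium channel 11 (Homo sapiens) as the target (on this read-out lower numbers stand for an effect already at smaller amounts and higher numbers for an effect only at larger amounts of compound), compound 1 `O=C(NCCCCCCCl)Nc1c(C(O)(C(F)(F)F)C(F)(F)F)ccc2ccccc12` gives 4840 nM; compound 2 `O=C(Nc1ccc(Cl)cc1)Nc1c(C(O)(C(F)(F)F)C(F)(F)F)ccc2ccccc12` gives 276 nM; compound 3 `CC(C)OC(=O)Nc1c(C(O)(C(F)(F)F)C(F)(F)F)ccc2ccccc12` gives 1160 nM. Compound 3 thus stands second highest of the three numbers, with a 4.2-fold lower number from compound 1 to compound 3 (0.62 log units; beyond the scatter) on one side and a 4.2-fold higher number from compound 2 to compound 3 (0.62 log units; beyond the scatter) on the other. Compound 4 `O=C(Nc1c(C(O)(C(F)(F)F)C(F)(F)F)ccc2ccccc12)c1cccc(Cl)c1` is not yet measured; it differs from compound 3 by 3-chlorophenyl in place of isopropoxy on a carbonyl carbon. Among the measured compounds shown here, the steps that bear on this are a 4.2-fold higher number from compound 2 to compound 3 (0.62 log units; beyond the scatter), where an aryl-bearing amide-type nitrogen on the carbonyl gave way to isopropoxy, and an 18-fold lower number from compound 1 to compound 2 (1.24 log units; beyond the scatter), where a chlorophenyl in place of a chloroalkyl chain on the amide-type nitrogen brought a large gain. For the measured compounds named here, both point to a chlorophenyl near the carbonyl favouring a lower number in this assay, though compound 4 carries the ring directly on the carbonyl carbon rather than through a nitrogen, for which no measured step exists. A modest step down, a 2.6-fold lower number from compound 3 to compound 4 (0.41 log units; beyond the scatter), is therefore expected. Compound 4 is estimated at 450 nM, with a range from 150 nM to 1500 nM.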

Compound 4, half-maximal effective concentration: 98 nM
The estimate for compound 4 lay 4.6-fold (0.66 log units) above the measured number; measured number outside the range, below it.
By their numbers in this assay, from the lowest: compound 4; then compound 2; then compound 3; then compound 1.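

In this assay, the carbonyl carbon tolerates more than a nitrogen or oxygen neighbour: a 3-chlorophenyl attached directly to it gives a 12-fold lower number from compound 3 to compound 4 (1.07 log units; beyond the scatter), and compound 4 now has the lowest number of the four. The ring does not need a nitrogen link to reach a low number, as shown by a 2.8-fold lower number from compound 2 to compound 4 (0.45 log units; beyond the scatter), although this step also moves the chlorine-bearing ring from 4-chlorophenyl to 3-chlorophenyl and so cannot be assigned to the nitrogen alone; the widest gap in the series is now a 49-fold lower number from compound 1 to compound 4 (1.69 log units; beyond the scatter). No measurement available here accounts for these steps.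

The compounds shown leave open what the chlorine itself contributes, and what a plain phenyl or a 4-chlorophenyl on the same carbonyl carbon would give. On these data alone, how a pyridine ring or a nitrile-bearing phenyl would read at this position also remains open.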